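This account rests on a few compounds, and the source may have more. Where it says the series, first, only, none or still open, it means among the compounds named here.

Measured compounds:
- compound 1, `O=[N+]([O-])c1ccc(-c2nc3cc(C(F)(F)F)ccc3[nH]2)cc1`: 6000 nM
- compound 2, `CC(=O)Nc1ccc(-c2nc3cc(C(F)(F)F)ccc3n2C2CCCCC2)cc1`: 24000 nM
- compound 3, `CC(=O)Nc1ccc(-c2nc3cc(C(F)(F)F)ccc3[nH]2)cc1`: 19000 nM

All three numbers come from an ADME assay on MT4 cells (Homo sapiens) for cytotoxicity, read by MTT assay, with a stated time of 96 h; a lower number here means that less compound is tolerated, a higher number that more compound is tolerated. Compound 2 gives the highest of the three, but its separation from compound 3 is a 1.3-fold lower number from compound 2 to compound 3 (0.10 log units; within the scatter), so the two are not distinguished here. Compound 3 and compound 1 are separated by a 3.2-fold lower number from compound 3 to compound 1 (0.50 log units; beyond the scatter), a step that does stand out of the scatter.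

The unmeasured compound 4, `O=[N+]([O-])c1ccc(-c2nc3cc(C(F)(F)F)ccc3n2C2CCCCC2)cc1`, is reached from compound 2 by nitro in place of acetamido on an aromatic carbon. The same change is already seen between compound 3 and compound 1, described as nitro in place of acetamido on an aromatic carbon; there it produced a 3.2-fold lower number from compound 3 to compound 1 (0.50 log units; beyond the scatter). The place lines of the two changes read the same word for word, so the change itself is the same. What differs between the two cores is cyclohexyl in place of hydrogen on an aromatic nitrogen, and that difference on its own moved the number only by a 1.3-fold lower number from compound 2 to compound 3 (0.10 log units; within the scatter), within the scatter.

With one precedent only, the expected step from compound 2 to compound 4 in this assay is a 3.2-fold lower number from compound 2 to compound 4 (0.51 log units; beyond the scatter), on the assumption that the step seen from compound 3 to compound 1, a 3.2-fold lower number from compound 3 to compound 1 (0.50 log units; beyond the scatter), carries over onto a core that differs merely by the cyclohexyl. Compound 4 is accordingly estimated at 7500 nM, with a likely range from 3500 nM to 16000 nM.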

Compound 4, half-maximal cytotoxic concentration: 49000 nM
The estimate for compound 4 lay 6.5-fold (0.82 log units) below the measured number; the whole stated range lies below it.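

In this assay, nitro in place of acetamido gives a 2.0-fold higher number from compound 2 to compound 4 (0.31 log units; beyond the scatter) on the core carrying cyclohexyl, so the step seen on the core with hydrogen on the aromatic nitrogen does not carry over, in direction or in size: the same change on two cores in this assay, a 3.2-fold lower number (0.50 log units; beyond the scatter) from compound 3 to compound 1 and a 2.0-fold higher number (0.31 log units; beyond the scatter) from compound 2 to compound 4, 6.5-fold (0.81 log units) apart, beyond the scatter of two such steps

Cyclohexyl in place of hydrogen on an aromatic nitrogen depends on its partner in the same way, giving an 8.2-fold higher number from compound 1 to compound 4 (0.91 log units; beyond the scatter) with nitro on the aromatic carbon, while compound 2 and compound 3, which carry acetamido, are not distinguished: the same change on two cores in this assay, a 1.3-fold lower number (0.10 log units; within the scatter) from compound 2 to compound 3 and an 8.2-fold lower number (0.91 log units; beyond the scatter) from compound 4 to compound 1, 6.5-fold (0.81 log units) apart, beyond the scatter of two such steps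

Across these four compounds the two changes therefore do not act independently, and a step read on one core is a poor guide to the other, but the data do not show why, and one pair per core gives no general rule for the series.

On these data alone, it remains open whether the opposite direction belongs to nitro alone or would also appear with other groups in that place, such as an amine or a carboxylic acid, on both cores. As far as these compounds go, it also remains open whether cyclohexyl itself is required, or whether a smaller group such as methyl on the aromatic nitrogen would behave in the same way.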